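The source may report more compounds than this note shows. Statements on the series, on what has been measured and on what is new or still open speak of the compounds shown alone.

Working notes on the series. In a functional assay on K562 cells (Homo sapiens) for antiproliferative activity, read by MTT assay, with a stated time of 48 h (a higher number here means a weaker inhibitor, a lower number a stronger inhibitor), compound 1 `O=C(/C=C/c1ccc(Cn2cc(Nc3ncc(Cl)c(Nc4ccc(F)cc4)n3)cn2)cc1)NO` gives 1030 nM as its read-out, compound 2 `COc1ccc(Nc2nc(Nc3cnn(CCCCCCC(=O)NO)c3)ncc2Cl)cc1` gives 620 nM and compound 3 `O=C(CCCCCn1cc(Nc2ncc(Cl)c(Nc3cccc(Cl)c3)n2)cn1)NO` gives 580 nM on the same measure. Compound 2 stands within the scatter of both compound 1 and compound 3, so the three numbers form one band with no order to read.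

Compound 4 `O=C(CCCCCCn1cc(Nc2ncc(Cl)c(Nc3ccc(F)cc3)n2)cn1)NO` is the next step from compound 2. The change is fluoro in place of methoxy on an aromatic carbon and amounts to fluoro in place of methoxy on an aromatic carbon, para to a large group, or 4-methoxyphenyl to 4-fluorophenyl. Within the data shown here, no measured pair isolates this change. Compound 1 also carries the 4-fluorophenyl group but differs elsewhere, and with 1030 nM as its value it stays within the band. The estimated step of a 1.0-fold lower number from compound 2 to compound 4 (0.01 log units; within the scatter) is therefore expected to stay within the scatter, with no direction favoured. The expected value for compound 4 is 600 nM with an estimated range of 250 nM to 1400 nM on that read-out.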

Compound 4, half-maximal inhibitory concentration: 500 nM
Compound 4: the middle estimate sits 1.2-fold (0.08 log units) above what was measured; the measured number falls inside the stated range.
By their numbers in this assay, from the lowest: compounds 4, 3, 2 and 1 (each within the scatter of the next, the first and the last beyond it).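

In this assay, among these compounds, fluoro in place of methoxy on this aromatic carbon, para to a large group, gives a 1.2-fold lower number from compound 2 to compound 4 (0.09 log units; within the scatter) and is the first change seen in isolation. Among the compounds shown here, at this position, on this read-out, 4-methoxyphenyl and 4-fluorophenyl cannot be told apart, which the earlier compounds could not show because each differs from the others in more than one place. No measured property of either group bears on this result.

The compounds shown leave open whether an amine or a carboxylic acid at this position would move the number beyond the scatter. They also leave open what a longer chain to the hydroxamic acid would do with the 4-fluorophenyl group held constant.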